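The source may hold more compounds than are shown below. What is called first, only, known or untested is meant among the compounds shown, and "the series" means these compounds.

Measured so far:
- compound 1 `O=C(c1ccncc1)N1N=C(c2cc3ccccc3o2)CC1/C=C/c1ccccc1`: > 212000 nM
- compound 2 `CCn1cc(C(=O)N2N=C(c3cc4ccccc4o3)CC2c2ccc(N(C)C)cc2)c(=O)c2ccc(C)nc21`: > 206000 nM

In an ADME assay on Vero cells (Chlorocebus sabaeus) for cytotoxicity, read by MTT assay, with a stated time of 72 h (on this read-out lower numbers stand for stronger inhibition and higher numbers for weaker inhibition), compound 1 gives only a limit, > 212000 nM. In this assay compound 2 likewise gives only a limit, > 206000 nM. Going by the values given here, both values shown for the series are limits the limit of > 206000 nM in this assay, at which 1 of the 2 values shown sits (the limit of > 212000 nM in this assay, at which 1 of the 2 values shown sits), so compound 2 stands level with the one other value known, and neither gives a number to rank. Among the compounds with values here, no step between measured compounds can be drawn from two limits.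

Compound 3 `CCn1cc(C(=O)N2N=C(c3cc4ccccc4o3)CC2c2ccccc2)c(=O)c2ccc(C)nc21` differs from compound 2 in one place: hydrogen in place of dimethylamino on an aromatic carbon. This change removes a small substituent and leaves the shared core and the rest of the molecule untouched. In this assay no shift beyond the usual scatter is expected from it. The expected step is a step that the limit leaves unreadable from compound 2 to compound 3, within the scatter. Compound 3 is expected to give 250000 nM, in the range 150000 nM to 500000 nM, and most probably the assay will again report only a limit rather than a number.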

Compound 3, half-maximal inhibitory concentration: > 210000 nM
Compound 3 ended at the assay's limit; the forecaster's own chance of this, stated with the estimate: 85%; the middle value is on the limit's open side.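

Compound 3 gives only a limit in this assay, > 210000 nM. Going by these compounds alone, compound 2 also gives only a limit, > 206000 nM, so no step from it to compound 3 can be read. The compounds shown leave open where any true half-maximal value lies in this assay, and whether the change from 4-(dimethylamino)phenyl to phenyl shifts it.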